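The source may hold more compounds than are shown below. What is called first, only, known or untested is meant among the compounds shown, and "the series" means these compounds.

Among the measured compounds shown here, in an assay for binding affinity to 17-beta-hydroxysteroid dehydrogenase type 2 (Homo sapiens), with a stated time of 20 min, tested at 1 uM (a lower number here means less inhibition, a higher number more inhibition at the concentration tested (going by the name of the read-out)), compound 3 `N#Cc1ccc(-c2ccc3c(O)cccc3c2)cc1` gives 12%, the only plain number among the three measured compounds. Compound 1 `Oc1ccc2cc(-c3ccccc3O)ccc2c1` gives < 10%, which is a limit of the assay rather than a number. Compound 2 `Oc1cccc2cc(-c3ccc(F)cc3)ccc12` likewise gives < 10%, again a limit and not a number. Where the other two sit is shown by the limit of < 10% in this assay, at which 2 of the 3 values shown sit. Compound 4 `CNS(=O)(=O)c1ccc(-c2ccc3c(O)cccc3c2)cc1` differs from compound 3 by methylsulfamoyl in place of cyano on an aromatic carbon. For the measured compounds named here, the one measured step at this position, a number at least 2 percentage points higher from compound 2 to compound 3 (that floor lies within the scatter), stays within the scatter, so a further exchange in the same place is expected to move the inhibition little. Compound 4 is therefore expected to give 12%, within a range from 4% to 24%, and the expected step of no change at the digits printed from compound 3 to compound 4 (within the scatter) lies within the scatter.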

Compound 4, a percentage reported as inhibition, at one concentration (the size of the read-out at that concentration, not a potency): 57%
Compound 4: the middle estimate sits 45 percentage points below what was measured; measured number above the stated range.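

The position turns out to be far more responsive than the earlier step between fluoro and cyano suggested: in this assay, methylsulfamoyl in place of cyano gives a number 45 percentage points higher from compound 3 to compound 4 (beyond the scatter), and methylsulfamoyl in place of fluoro gives a number at least 47 percentage points higher from compound 2 to compound 4 (beyond the scatter). The second step is only a floor, since compound 2 stands at a limit of the assay: the limit of < 10% in this assay, at which 2 of the 4 values shown sit.

Going by these compounds, how an unsubstituted sulfamoyl, a dimethylsulfamoyl or a carboxylic acid would fare in this place stays open. On these data alone, with a read-out at a single concentration, the potency of compound 4 also stays open.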